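A thiophene in place of chlorophenyl on compound 1

The source may report more compounds than this note shows. Statements on the series, on what has been measured and on what is new or still open speak of the compounds shown alone.

Compound 1 `COc1cc(-c2cc(-c3ccc(Cl)cc3)nc(-c3ccccc3)n2)cc(OC)c1OC` reaches only the limit of > 25000 nM in a functional assay on MDA-MB-231 cells (Homo sapiens) for inhibition, read by MTT assay, with a stated time of 48 h (on this read-out lower numbers stand for stronger inhibition and higher numbers for weaker inhibition), so no number is known for it. Compound 2 `COc1cc(-c2cc(-c3cccc4ccccc34)nc(-c3ccccc3)n2)cc(OC)c1OC` gives 3240 nM in this assay. The step of an at least 7.7-fold lower number from compound 1 to compound 2 (0.88 log units; beyond the scatter) shows that exchanging the 4-chlorophenyl on that aromatic carbon can lower the number. Compound 3 `COc1cc(-c2cc(-c3cccs3)nc(-c3ccccc3)n2)cc(OC)c1OC` differs from compound 1 by thiophen-2-yl in place of 4-chlorophenyl on an aromatic carbon. Among the measured compounds shown here, only this one step bears on the change, and it starts from a limit (the limit of > 25000 nM in this assay, at which 1 of the 2 values shown sits), so its full size is uncertain. A smaller lowering is expected, an at least 2.0-fold lower number from compound 1 to compound 3 (0.31 log units; beyond the scatter). Compound 3 is therefore estimated at 12000 nM, between 3000 nM and 30000 nM.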

Compound 3, half-maximal inhibitory concentration: 5110 nM
The estimate for compound 3 lay 2.3-fold (0.37 log units) above the measured number, within the range that was stated.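

In this assay, thiophen-2-yl in place of the 4-chlorophenyl gives an at least 4.8-fold lower number from compound 1 to compound 3 (0.68 log units; beyond the scatter), so at this position the lowering is not confined to naphthalen-1-yl. The two replacements cannot be told apart, with a 1.6-fold higher number from compound 2 to compound 3 (0.20 log units; within the scatter). The full size of both lowerings remains uncertain because compound 1 has only a limit, not a number: the limit of > 25000 nM in this assay, at which 1 of the 3 values shown sits.

The compounds shown leave open whether a furan-2-yl or a pyridin-2-yl would serve at this position as thiophen-2-yl does. They also leave open what an amine or a carboxylic acid on the thiophene would do.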